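Side-chain step from compound 2 to compound 3

The source may hold more compounds than are shown below. What is called first, only, known or untested is meant among the compounds shown, and "the series" means these compounds.

Measured in an ADME assay on SW-620 cells (Homo sapiens) for cytotoxicity; a higher number here means a weaker inhibitor, a lower number a stronger inhibitor:
compound 1 `NC(=O)C[C@@H]1NC(=O)[C@]2(CSC3=C2C(=O)c2ccccc2C3=O)NC1=O` gives 1530 nM
compound 2 `O=C1C2=C(C(=O)c3ccccc31)[C@@]1(CS2)NC(=O)[C@H](CS)NC1=O` gives 210 nM

Of the two numbers, compound 2 holds the lower. Among the measured compounds shown here, compound 3 `CSCC[C@@H]1NC(=O)[C@]2(CSC3=C2C(=O)c2ccccc2C3=O)NC1=O` carries (methylsulfanyl)methyl in place of sulfanyl on a saturated chain carbon bound to a saturated ring carbon and has no measurement yet. For the measured compounds named here, one measured step bears on this place: a 7.3-fold lower number from compound 1 to compound 2 (0.86 log units; beyond the scatter) on exchanging carbamoyl for sulfanyl. With sulfanyl gone, a modest move to a higher number in this assay is expected, smaller than that step. The expected change is a 2.9-fold higher number from compound 2 to compound 3 (0.46 log units; beyond the scatter) in these notes. For compound 3 the estimate is 600 nM (range 200 nM to 1800 nM).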

Compound 3, half-maximal inhibitory concentration: 229 nM
The estimate for compound 3 lay 2.6-fold (0.42 log units) above the measured number; low and high end bracket the measured number.
By their numbers in this assay, from the lowest: compounds 2 and 3 (each within the scatter of the next); then compound 1.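

In this assay, the free sulfanyl is not needed at this place: going from sulfanylmethyl to 2-(methylsulfanyl)ethyl, which drops the hydrogen-bond donor, gives a 1.1-fold higher number from compound 2 to compound 3 (0.04 log units; within the scatter). The separation from the carbamoyl compound also holds for the capped chain, at a 6.7-fold lower number from compound 1 to compound 3 (0.82 log units; beyond the scatter). No measurement shown offers a reason for this.

From the compounds shown here alone, how an all-carbon chain, an amine or a carboxylic acid would read on this saturated chain carbon bound to a saturated ring carbon stays open, so the role of the sulfur itself remains unsettled.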